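A few compounds are considered here, and "the series" means these few. Any claim that something is new, unique, unknown or untested is made for them only; others in the source may bear on it.

Compound 1 `COc1ncnc2c1c(-c1ccoc1)cn2[C@@H]1O[C@H](CO)[C@@H](O)[C@H]1O` in a functional assay on K562 cells (Homo sapiens), read by MTT assay, with a stated time of 72 h (on this read-out lower numbers stand for stronger inhibition and higher numbers for weaker inhibition), gives 2820 nM. Compound 2 `Cc1ncnc2c1c(-c1ccoc1)cn2[C@@H]1O[C@H](CO)[C@@H](O)[C@H]1O` reaches only a limit of this assay, > 20000 nM. The change from compound 1 to compound 2 is methyl in place of methoxy on an aromatic carbon; the step is an at least 7.0-fold higher number from compound 1 to compound 2 (0.85 log units; beyond the scatter), and its size rests on the limit (the limit of > 20000 nM in this assay, at which 1 of the 3 values shown sits). Compound 3 `COc1ncnc2c1c(-c1cccs1)cn2[C@@H]1O[C@H](CO)[C@@H](O)[C@H]1O` gives 6200 nM in this assay; it differs from compound 1 by thiophen-2-yl in place of furan-3-yl on an aromatic carbon, with a step of a 2.2-fold higher number from compound 1 to compound 3 (0.34 log units; beyond the scatter). Compound 4 `Cc1ncnc2c1c(-c1cccs1)cn2[C@@H]1O[C@H](CO)[C@@H](O)[C@H]1O` is not yet measured in this assay; it differs from compound 3 by methyl in place of methoxy on an aromatic carbon, the same change as from compound 1 to compound 2, at the same place. Because compound 1 to compound 2 gave an at least 7.0-fold higher number from compound 1 to compound 2 (0.85 log units; beyond the scatter), the step from compound 3 is expected to be of comparable size, estimated as a 7.3-fold higher number from compound 3 to compound 4 (0.86 log units; beyond the scatter). Compound 4 is accordingly estimated at 45000 nM, most probably returned as a limit.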

Compound 4, half-maximal inhibitory concentration: > 20000 nM
Compound 4: only a limit was reported; the forecaster's own chance of this, stated with the estimate: 75%; the middle value is on the limit's open side.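

Methyl in place of methoxy gives a higher number on the second core as well in this assay, with an at least 3.2-fold higher number from compound 3 to compound 4 (0.50 log units; beyond the scatter), so the direction of the change holds in these two pairs. How far its size carries from one core to the other is not shown: the same change on two cores in this assay, an at least 7.0-fold higher number (0.85 log units; beyond the scatter) from compound 1 to compound 2 and an at least 3.2-fold higher number (0.50 log units; beyond the scatter) from compound 3 to compound 4; the limit leaves it open whether they differ. Both methyl compounds are limits rather than numbers, and the step between them, thiophen-2-yl in place of furan-3-yl, cannot be read: the limit of > 20000 nM in this assay, at which 2 of the 4 values shown sit.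

The compounds shown leave open whether an amine or an ethoxy group at this place would keep a measurable value. They also leave open how far compound 2 and compound 4 lie beyond the limit.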